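Replacing the selenium-bearing chain of compound 1 with 2-aminoethoxy

The source may report more compounds than this note shows. Statements on the series, on what has been measured and on what is new or still open speak of the compounds shown alone.

Two compounds of this series have a number in a functional assay on LoVo cells (Homo sapiens) for inhibition, read by MTT assay, with a stated time of 48 h; on this read-out lower numbers stand for stronger inhibition and higher numbers for weaker inhibition. Compound 1 `COc1ccc(N(C)c2nc(C)nc3ccccc23)cc1C(=O)OCC[Se]C#N` gives 2960 nM, the highest of the two. Compound 2 `CN(c1ccc([Se]C#N)cc1)c1nc(C2CC2)nc2ccccc12` gives 11 nM in this assay, a gap far beyond the scatter; the two differ in several places, so no single step can be read from them.

Compound 3 `COc1ccc(N(C)c2nc(C)nc3ccccc23)cc1OCCN` has not been measured. It departs from compound 1 by a group of 4 heavy atoms (2 carbon, 1 nitrogen, 1 oxygen; no ring) in place of a group of 8 heavy atoms (4 carbon, 1 nitrogen, 2 oxygen, 1 selenium; no ring), on an aromatic carbon. For the measured compounds named here, no measured pair shows a change of this kind, so the size of the step is open. Going by the values given here, the only compound with a low number, compound 2 at 11 nM, keeps selenium in its structure, whereas compound 3 keeps none. On that basis compound 3 is expected to sit on the weaker side, with an estimated step of a 2.7-fold higher number from compound 1 to compound 3 (0.43 log units; beyond the scatter). The estimate for compound 3 in this assay is 8000 nM, within 2000 nM to 30000 nM.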

Compound 3, half-maximal inhibitory concentration: 421 nM
Beside the measured number, compound 3's estimate is 19-fold (1.28 log units) above it; the measured number lies below the stated range.
By their numbers in this assay, from the lowest: compound 2; then compound 3; then compound 1.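

In this assay, the place ortho to a methoxy group accepts the loss of the whole selenium-bearing chain: 2-aminoethoxy there gives a 7.0-fold lower number from compound 1 to compound 3 (0.85 log units; beyond the scatter). For the compounds shown here, on the core of compound 1, selenium is therefore not required at this place for a lower number, and this is the first single-place step read. The change replaces the whole group at once, so the step cannot be divided among selenium, the carbonyl and chain size, and no measurement at hand gives a reason for it.

Open, going by these compounds, is whether the terminal amine carries the step: a 2-hydroxyethoxy or plain ethoxy group at this place would separate it from the ether chain. Also open, on these data alone, are a longer chain such as 3-aminopropoxy and a dimethylamino end in place of the primary amine.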